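The source may report more compounds than this note shows. Statements on the series, on what has been measured and on what is new or still open speak of the compounds shown alone.

In a functional assay on HeLa cells (Homo sapiens) for inhibition, read by MTT assay, with a stated time of 72 h (on this read-out higher numbers stand for weaker inhibition and lower numbers for stronger inhibition), the measured compounds are:

compound 1 `COc1ccc(-c2nnc(SCCCN3CCN(c4nc5ccccc5s4)CC3)o2)cc1`: 165000 nM
compound 2 `Clc1ccc(-c2nnc(SCCCN3CCN(c4nc5ccccc5s4)CC3)o2)cc1`: 177000 nM
compound 3 `Brc1ccc(-c2nnc(SCCCN3CCN(c4nc5ccccc5s4)CC3)o2)cc1`: 243000 nM

These three values cannot be told apart. Compound 3, at 243000 nM, stays within the scatter of both other compounds, as a 1.5-fold higher number from compound 1 to compound 3 (0.17 log units; within the scatter) and a 1.4-fold higher number from compound 2 to compound 3 (0.14 log units; within the scatter) show. The remaining comparison, a 1.1-fold higher number from compound 1 to compound 2 (0.03 log units; within the scatter), gives the same picture.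

The next compound, compound 4 `O=C(NCc1nnc(SCCCN2CCN(c3nc4ccccc4s3)CC2)o1)c1ccccc1`, keeps the rest of the structure and changes one group: benzamidomethyl in place of 4-bromophenyl on an aromatic carbon. In words, this is benzamidomethyl in place of 4-bromophenyl on an aromatic carbon of a five-membered aromatic ring with 2 nitrogen and 1 oxygen.

The measured steps offer only limited guidance. Each exchanged one single group among methoxy, chloro and bromo, whereas this change replaces the whole 4-bromophenyl group. Going by the values given here, no measured compound carries a benzamidomethyl group, so the data show no direction for this change. The flat result in this assay supports expecting no step beyond the scatter, but with a wide margin on either side.

For compound 4, the estimated value is 170000 nM, with an expected range from 60000 nM to 400000 nM. The expected change is a 1.4-fold lower number from compound 3 to compound 4 (0.16 log units; within the scatter).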

Compound 4, half-maximal inhibitory concentration: 78100 nM
The estimate for compound 4 lay 2.2-fold (0.34 log units) above the measured number, and the stated range covers the measured number.
By their numbers in this assay, from the lowest: compound 4; then compounds 1, 2 and 3 (each within the scatter of the next).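

In this assay, the three earlier compounds differed only in one group on the phenyl ring and stayed within the scatter of each other, but replacing the whole aryl group gives steps beyond it (a 3.1-fold lower number from compound 3 to compound 4 (0.49 log units; beyond the scatter)) (a 2.3-fold lower number from compound 2 to compound 4 (0.36 log units; beyond the scatter)) (a 2.1-fold lower number from compound 1 to compound 4 (0.32 log units; beyond the scatter)). This shows that the aromatic carbon of the five-membered aromatic ring with 2 nitrogen and 1 oxygen can respond to a change of group, although the steps are modest and compound 4 is the strongest inhibitor of the four only by this margin. Benzamidomethyl differs from the aryl groups in size and in carrying a hydrogen-bond donor and acceptor, and nothing available explains which of these differences, if any, matters.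

A benzyl group, which has the phenyl ring without the amide, and an acetamidomethyl group, which has the amide without the phenyl ring, would help separate the two parts of the new group. Going by these compounds, it also remains open whether an amine or a carboxylic acid at this position would move the number further in either direction.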